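The source may hold more compounds than are shown below. What is called first, only, known or untested is meant among the compounds shown, and "the series" means these compounds.

Measured compounds:
- compound 1, `Cc1nc(S(C)(=O)=O)ccc1Oc1ncnc(OC2CCN(C(=O)OC(C)F)CC2)c1F`: 68%
- compound 2, `Cc1nc(S(C)(=O)=O)ccc1Oc1ncnc(OC2CCN(C(=O)OC3(C(F)(F)F)CCC3)CC2)c1F`: 82%
- compound 3, `Cc1nc(S(C)(=O)=O)ccc1Oc1ncnc(OC2CCN(C(=O)OC3(C(F)(F)F)COC3)CC2)c1F`: 84%

In a functional assay on isolated protein for inhibition of Glucose-dependent insulinotropic receptor (Rattus norvegicus), read by HTRF and cAMP accumulation (on this read-out higher numbers stand for larger maximal responses and lower numbers for smaller maximal responses), compound 3 cannot be told apart from compound 2, since a number 2 percentage points higher from compound 2 to compound 3 (within the scatter), but both stand apart from compound 1, because a number 16 percentage points higher from compound 1 to compound 3 (beyond the scatter) and a number 14 percentage points higher from compound 1 to compound 2 (beyond the scatter). Compound 4, `Cc1nc(S(C)(=O)=O)ccc1Oc1ncnc(OC2CCN(C(=O)C(F)(F)F)CC2)c1F`, is not yet measured. The change from compound 3 is trifluoromethyl in place of (3-(trifluoromethyl)oxetan-3-yl)oxy on a carbonyl carbon. Among the measured compounds shown here, no measured step removes the oxygen-bound group from the carbonyl carbon; the two steps from compound 1 only show that replacing 1-fluoroethyl with a ring-bearing group raised the response modestly. Since compound 4 carries a group of a size closer to that of compound 1, a modest fall is expected, a number 18 percentage points lower from compound 3 to compound 4 (beyond the scatter), with compound 4 estimated at 66%, between 50% and 82%.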

Compound 4, largest response reached (reported as efficacy), in percent of the reference or control that the assay uses: 76%
Compound 4: middle estimate off by 10 percentage points, on the low side; measured number inside the range.
By their numbers in this assay, from the lowest: compounds 1, 4, 2 and 3 (each within the scatter of the next, the first and the last beyond it).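

In this assay the ring-bearing, oxygen-linked groups on this carbonyl carbon give way to plain trifluoromethyl without a readable difference, as shown by a number 8 percentage points lower from compound 3 to compound 4 (within the scatter) and by a number 6 percentage points lower from compound 2 to compound 4 (within the scatter) in the same way. The smaller group of compound 1 gives no readable difference either, with a number 8 percentage points higher from compound 1 to compound 4 (within the scatter) here, so compound 4 cannot be told apart from any earlier compound, even though compound 1 stands apart from compound 2 and compound 3. No measurement shown explains this result.

Still open, on these data alone, is whether an amine on this carbonyl carbon, such as dimethylamino, would fit the same picture. The same question applies to a longer chain, such as pentafluoroethyl.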